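The source may report more compounds than this note shows. Statements on the series, on what has been measured and on what is new or still open speak of the compounds shown alone.

Measured so far:
compound 1, `C[C@@H]1CN(c2sc(Br)nc2-c2nc3ccccc3[nH]2)CCN1C(=O)Cn1cnc2cccnc21`, 126 nM
compound 2, `CCOc1ncc(-c2nc(C(F)(F)F)sc2N2CCN(C(=O)Cn3nc(C)cc3C)[C@H](C)C2)cn1`, 87 nM
compound 3, `Cc1nc(C)n(CC(=O)N2CCN(c3sc(C(F)(F)F)nc3-c3cnc(OC4CCC4)nc3)C[C@H]2C)n1`, 78 nM

These three compounds were tested in a functional assay on U2OS cells for antagonist activity at C-X-C chemokine receptor type 3 (Homo sapiens), read by beta-arrestin recruitment; on this read-out higher numbers stand for weaker inhibition and lower numbers for stronger inhibition. Compound 3 gives the lowest of the three numbers, but its gaps to compound 2 and to compound 1 both fall within the usual scatter, so the three cannot be ranked against each other.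

Compound 4, `COc1ccc(-c2nc(C(F)(F)F)sc2N2CCN(C(=O)Cn3nc(C)nc3C)[C@H](C)C2)cn1`, has not been measured yet. It differs from compound 3 in one place: 6-methoxypyridin-3-yl in place of 2-(cyclobutyloxy)pyrimidin-5-yl on an aromatic carbon. Among the measured compounds shown here, no pair of measured compounds shows what such a swap does, so there is nothing to set the size or direction of the step. The expectation is therefore a step from compound 3 to compound 4 of a 1.4-fold higher number from compound 3 to compound 4 (0.15 log units; within the scatter), close to no change beyond the scatter. Compound 4 is estimated at 110 nM, with a range of 40 nM to 300 nM.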

Compound 4, half-maximal inhibitory concentration: 1170 nM
For compound 4 the middle estimate is 11-fold (1.03 log units) below the measured one; measured number above the stated range.
By their numbers in this assay, from the lowest: compounds 3, 2 and 1 (each within the scatter of the next); then compound 4.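

In this assay the group on this aromatic carbon of the shared core clearly matters: 6-methoxypyridin-3-yl in place of 2-(cyclobutyloxy)pyrimidin-5-yl gives a 15-fold higher number from compound 3 to compound 4 (1.18 log units; beyond the scatter) and this is the only step beyond the scatter among these compounds. The swap changes both the ring and the group on its oxygen, so this single step cannot show which change carries the weaker inhibition. Nothing available here explains the step.

Still open, from the compounds shown here alone, is whether a pyrimidine ring carrying methoxy, or a pyridine ring carrying cyclobutyloxy, would stay close to compound 3 or fall toward compound 4.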